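Exchange of the six-membered lactone ring in compound 4

The source may hold more compounds than are shown below. What is called first, only, known or untested is meant among the compounds shown, and "the series" means these compounds.

Compound 3 `CC(=O)O[C@H](C[C@@H](O)C[C@H](O)/C=C/c1ccccc1)C[C@@H]1OC(=O)C=C[C@@H]1O` carries an acetyl on an oxygen on a saturated carbon and a hydroxy on a saturated ring carbon. In a functional assay on RAW264.7 cells (Mus musculus) for inhibition, read by Griess assay, with a stated time of 18 h (a higher number here means a weaker inhibitor, a lower number a stronger inhibitor), compound 3 gives 27600 nM, and it stands alongside compound 2 `O=C1C=C[C@H](O)[C@H](C[C@H](O)C[C@@H](O)C[C@H](O)/C=C/c2ccccc2)O1`, which gives 13800 nM; the step of a 2.0-fold higher number from compound 2 to compound 3 (0.30 log units; within the scatter) lies within the scatter. Compound 1 `CC(=O)O[C@H](C[C@@H](O)C[C@H](O)/C=C/c1ccccc1)C[C@H]1CC=CC(=O)O1` reaches only the limit > 50000 nM and no number (the limit of > 50000 nM in this assay, at which 1 of the 3 values shown sits). The step of an at least 1.8-fold lower number from compound 1 to compound 3 (0.25 log units; that floor lies within the scatter) is the only one that touches the six-membered non-aromatic ring, and its floor lies within the scatter.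

Compound 4 `CC(=O)O[C@@H](C/C=C1/C=CC(=O)O1)C[C@@H](O)C[C@H](O)/C=C/c1ccccc1` differs from compound 3 as follows: a group of 7 heavy atoms (5 carbon, 2 oxygen; one five-membered non-aromatic ring with 1 hetero atom) in place of a group of 8 heavy atoms (5 carbon, 3 oxygen; one six-membered non-aromatic ring with 1 hetero atom), on a saturated chain carbon, two bonds along the chain from an oxygen next to a carbonyl group. For the measured compounds named here, no measured step exchanges this ring, and the two steps in hand give no direction for the change; the expected step of a 1.1-fold higher number from compound 3 to compound 4 (0.04 log units; within the scatter) is therefore set near zero, with a wide range. Compound 4 is estimated at 30000 nM in this assay, from 8000 nM to 100000 nM.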

Compound 4, half-maximal inhibitory concentration: 3400 nM
For compound 4 the middle estimate is 8.8-fold (0.95 log units) above the measured one, outside the stated range (below it).
By their numbers in this assay, from the lowest: compound 4; then compounds 2 and 3 (each within the scatter of the next). At a limit, above all of these: compound 1.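

In this assay, for the compounds shown here, exchanging the six-membered non-aromatic ring for the five-membered non-aromatic ring is the first change at this saturated chain carbon that goes beyond the scatter: an 8.1-fold lower number from compound 3 to compound 4 (0.91 log units; beyond the scatter). Starting instead from the six-membered ring that lacks the ring hydroxy, the same exchange gives an at least 14-fold lower number from compound 1 to compound 4 (1.16 log units; beyond the scatter), so the lower number does not depend on removal of that hydroxy. That step is only a floor, as compound 1 stands at a limit and not at a number: the limit of > 50000 nM in this assay, at which 1 of the 4 values shown sits.

Compound 4 alone carries the five-membered ring, so ring size cannot be separated from the extra double bond outside aromatic rings that enters with it. The compounds shown also leave open whether the lower number holds with a free hydroxy in place of the acetyl, or with an amine on the five-membered ring.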